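This account rests on a few compounds, and the source may have more. Where it says the series, first, only, none or still open, it means among the compounds named here.

Compound 1, `[N-]=[N+]=N[C@H]1C[C@H](n2cnc3c(NCCCCCO)nc(N)nc32)O[C@@H]1CO`, gives > 100000 nM in an ADME assay on PBMC cells (Homo sapiens) for cytotoxicity, with a stated time of 5 days; a higher number here means a weaker inhibitor, a lower number a stronger inhibitor; this is a limit of the assay, not a number.
Compound 2, `[N-]=[N+]=N[C@H]1C[C@H](n2cnc3c(N)nc(F)nc32)O[C@@H]1CO`, gives 30100 nM in this assay.
Compound 3, `COc1nc(Cl)nc2c1ncn2[C@H]1C[C@H](N=[N+]=[N-])[C@@H](CO)O1`, gives > 100000 nM in this assay; this is a limit of the assay.

Among the three measured compounds, compound 1 stands at the weak end of this assay: its result is a limit only, with no number attached. Two of the three values recorded sit at that limit, (the limit of > 100000 nM in this assay, at which 2 of the 3 values shown sit), and only compound 2 gives a number inside the measurable range. Going by the values given here, no two of the measured compounds differ in a single place, so there is no measured step to rest on.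

Compound 4, `C#CCNc1nc(N)nc2c1ncn2[C@H]1C[C@H](N=[N+]=[N-])[C@@H](CO)O1`, has not yet been measured. It differs from compound 1 in one place: ethynyl in place of 4-hydroxybutyl on a saturated chain carbon bound to a nitrogen on an aromatic ring. Compound 1 itself returns only a limit. No shift beyond the usual scatter is expected, so the step of a number no higher from compound 1 to compound 4 (the limit leaves the size open) is estimated to be small. Compound 4 is therefore expected near 100000 nM, with a range from 30000 nM to 300000 nM, and a real chance that this assay again reports only a limit rather than a number.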

Compound 4, half-maximal inhibitory concentration: > 100000 nM
Compound 4: only a limit was reported (the forecaster's own chance of this, stated with the estimate: 60%); the middle value lies on the limit itself.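

Compound 1 and compound 4 both return only a limit in this assay, so the step between them cannot be read: the limit of > 100000 nM in this assay, at which 3 of the 4 values shown sit. The compounds shown leave open whether ethynyl in place of 4-hydroxybutyl changes the result in this assay at all, as neither compound has a number to compare.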